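Chloro removal on the benzyloxy ring of compound 2

This account rests on a few compounds, and the source may have more. Where it says the series, first, only, none or still open, it means among the compounds named here.

Measured so far:
compound 1 `Cc1cccc2ncnc(O/N=C(\C=C\c3ccccn3)/C=C/c3ccccc3OCc3ccccc3Cl)c12`, 95.7%
compound 2 `Cc1cccc2ncnc(O/N=C(\C=C\c3ccccn3)/C=C/c3ccccc3OCc3ccc(Cl)cc3Cl)c12`, 93.9%

Both numbers come from a functional assay on SMMC-7721 cells (Homo sapiens) for inhibition, read by MTT assay, with a stated time of 72 h, tested at 10 uM; a higher number here means a stronger effect of the compound at the concentration tested, a lower number a weaker effect. Compound 2 and compound 1 lie within the usual scatter of each other; on the two numbers shown the pair cannot be separated. For the measured compounds named here, the one step in hand, a number 1.8 percentage points lower from compound 1 to compound 2 (within the scatter), exchanges hydrogen for chloro on an aromatic carbon of the same benzyloxy ring and gives no movement beyond the scatter.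

Compound 3 `Cc1cccc2ncnc(O/N=C(\C=C\c3ccccn3)/C=C/c3ccccc3OCc3ccc(Cl)cc3)c12` is not yet measured. Its difference from compound 2 is hydrogen in place of chloro on an aromatic carbon, read one bond further out as 2,4-dichlorobenzyl to 4-chlorobenzyl. Going by the values given here, the only step that bears on it, a number 1.8 percentage points lower from compound 1 to compound 2 (within the scatter), is of the same kind, chloro against hydrogen on this ring, though at a different aromatic carbon, and it stayed within the scatter. On that basis no step beyond the scatter is expected in this assay for compound 3. Compound 3 is therefore estimated at 93%, range 84% to 99%, which means an expected step of a number 0.9 percentage points lower from compound 2 to compound 3 (within the scatter).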

Compound 3, a percentage reported as inhibition, at one concentration (the size of the read-out at that concentration, not a potency): 94.5%
Estimate against measurement, compound 3: 1.5 percentage points below, and the stated range covers the measured number.
By their numbers in this assay, from the lowest: compounds 2, 3 and 1 (each within the scatter of the next).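

In this assay, going from 2,4-dichlorobenzyl to 4-chlorobenzyl gives a number 0.6 percentage points higher from compound 2 to compound 3 (within the scatter), so at this aromatic carbon, ortho to a large group and meta to a chloro group, hydrogen and chloro cannot be separated while the other chloro stays in place. The placement of a single chloro is now also covered: 4-chlorophenyl in place of 2-chlorophenyl gives a number 1.2 percentage points lower from compound 1 to compound 3 (within the scatter), which the earlier pair could not show, and the 2-chloro, 4-chloro and 2,4-dichloro patterns all lie within the scatter of one another. No independent data bear on why these three patterns read alike.

Every compound shown keeps at least one chloro on this ring, so it remains open whether the unsubstituted benzyl group, or a methoxy group or an amine in place of the chloro, would read the same. Going by these compounds, these are also read-outs at one concentration and not potencies, so whether compounds 1, 2 and 3 would still be inseparable at lower concentrations remains open too.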